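The source may hold more compounds than are shown below. What is called first, only, known or untested is meant among the compounds shown, and "the series" means these compounds.

Compound 1 `O=S(=O)(/C=C/c1ccc(O)c(O)c1)CCCCCCCO`: 5900 nM
Compound 2 `CCCCCCCCS(=O)(=O)/C=C/c1ccc(O)c(O)c1`: 6400 nM

Both numbers come from a functional assay, read by fluorescence and spectrophotometry, with a stated time of 1 h; a higher number here means that more compound is needed for the effect, a lower number that less compound is needed. There, compound 2 at 6400 nM cannot be told apart from compound 1, since the two lie within the usual scatter of each other. Compound 3 `O=S(=O)(/C=C/c1ccc(O)c(O)c1)CCCc1ccccc1` has not yet been measured. It differs from compound 2 as follows: phenyl in place of pentyl on a saturated chain carbon, three bonds along the chain from a sulfonyl sulfur. This places phenyl in place of pentyl on a saturated chain carbon, three bonds along the chain from a sulfonyl sulfur. For the measured compounds named here, only one measured step bears on this: a 1.1-fold higher number from compound 1 to compound 2 (0.04 log units; within the scatter). That step was a different change, methyl in place of hydroxy, seven bonds along the chain from a sulfonyl sulfur, so it is only a loose guide. The estimate is therefore a 1.2-fold lower number from compound 2 to compound 3 (0.07 log units; within the scatter), and no clear shift in either direction is expected. For compound 3 the expected value is 5500 nM, with an estimated range from 2000 nM to 14000 nM.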

Compound 3, half-maximal effective concentration: 11500 nM
Beside the measured number, compound 3's estimate is 2.1-fold (0.32 log units) below it; the range from low to high includes it.
By their numbers in this assay, from the lowest: compounds 1, 2 and 3 (each within the scatter of the next).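

Until now, the chain on the sulfonyl sulfur had only been varied as an open chain, so it was unclear whether a ring could sit there. In this assay, phenyl in place of pentyl, on a saturated chain carbon three bonds along the chain from the sulfonyl sulfur, gives a 1.8-fold higher number from compound 2 to compound 3 (0.25 log units; within the scatter), and phenyl in place of 4-hydroxybutyl gives a 1.9-fold higher number from compound 1 to compound 3 (0.29 log units; within the scatter), so neither step can be told apart from repeat-measurement noise and this position tolerates a six-membered aromatic ring as well as it tolerates the open chains. Nothing available explains this tolerance.

As far as these compounds go, it remains open whether a ring carrying a substituent, such as a chloro or methoxy group, would behave in the same way. An amine or a carboxylic acid at the end of the chain, or a longer chain leading to the phenyl ring, could also give a different result.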